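Swapping One Side Group on a Growth Inhibitor

A few compounds are considered here, and "the series" means these few. Any claim that something is new, unique, unknown or untested is made for them only; others in the source may bear on it.

In a functional assay on HCT-116 cells (Homo sapiens) for inhibition, read by MTT assay, with a stated time of 72 h (a lower number here means a stronger inhibitor of growth, a higher number a weaker inhibitor of growth), compound 1 (`CN(C)c1ccc(-c2nc3c(N4CCN(Cc5ccncc5)CC4)c(Br)cnc3[nH]2)cc1`) gives 700 nM while compound 2 (`CN(C)Cc1ccc(-c2nc3c(N4CCN(CC(=O)Nc5nccs5)CC4)c(Br)cnc3[nH]2)cc1`) gives 1000 nM which lies within the usual scatter of compound 1. Compound 3 (`CN(C)c1ccc(-c2nc3c(N4CCN(CC(=O)Nc5nccs5)CC4)c(Br)cnc3[nH]2)cc1`) is compound 2 with dimethylamino in place of (dimethylamino)methyl on an aromatic carbon. For the measured compounds named here, no measured pair shows this change on its own. Compound 1 also carries dimethylamino and gives 700 nM so no shift beyond the scatter is expected. The estimated step of a 1.3-fold lower number from compound 2 to compound 3 (0.10 log units; within the scatter) is expected to stay within the scatter in this assay with only a slight lean toward a lower number. Compound 3 is estimated at 800 nM with 300 nM to 2000 nM as the expected range.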

Compound 3, concentration for 50% growth inhibition: 480 nM
The estimate for compound 3 lay 1.7-fold (0.22 log units) above the measured number, within the range that was stated.
By their numbers in this assay, from the lowest: compounds 3, 1 and 2 (each within the scatter of the next, the first and the last beyond it).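

In this assay, for the compounds shown here, dimethylamino in place of (dimethylamino)methyl on the aromatic carbon gives a 2.1-fold lower number from compound 2 to compound 3 (0.32 log units; beyond the scatter) and is the first sign that this position responds to the change, though only modestly. With dimethylamino held fixed, (1,3-thiazol-2-yl)carbamoyl in place of pyridin-4-yl gives a 1.5-fold lower number from compound 1 to compound 3 (0.16 log units; within the scatter) and so shows no clear effect of that swap. No measurement here explains why the shorter group reads lower.

Going by these compounds, how a plain amino group or a longer chain such as 2-(dimethylamino)ethyl would read on that carbon remains open. On these data alone, whether the same step holds with pyridin-4-yl on the other side of the molecule also remains open.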